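Two Methoxy Steps and a Catechol Still to Measure

The source may hold more compounds than are shown below. What is called first, only, known or untested is meant among the compounds shown, and "the series" means these compounds.

Compound 1, `COc1ccc(/C=C2\CCC/C(=C\c3cccc(OC)c3OC)C2=O)cc1OC`: 14900 nM
Compound 2, `COc1cccc(/C=C2\CCC/C(=C\c3ccc(OC)c(OC)c3)C2=O)c1`: 11600 nM
Compound 3, `COc1cc(/C=C2\CCC/C(=C\c3ccc(OC)c(OC)c3)C2=O)cc(OC)c1`: 6500 nM

Three analogues share one core and were measured in an ADME assay on NHDF cells (Homo sapiens) for cytotoxicity, read by MTT assay, with a stated time of 72 h; a lower number here means a stronger inhibitor, a higher number a weaker inhibitor. Compound 2 sits between its two neighbours: compound 1 is the nearer, separated by a 1.3-fold lower number from compound 1 to compound 2 (0.11 log units; within the scatter), and compound 3 the further, separated by a 1.8-fold lower number from compound 2 to compound 3 (0.25 log units; within the scatter). Both steps are changes of a single methoxy group on an aromatic carbon, and neither leaves the scatter.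

Compound 4, `COc1ccc(/C=C2\CCC/C(=C\c3ccc(O)c(O)c3)C2=O)cc1OC`, has not yet been measured in this assay. From compound 2 the change is 3,4-dihydroxyphenyl in place of 3-methoxyphenyl on a double-bonded chain carbon bound to a double-bonded ring carbon. Among the compounds with values here, no measured step in this set exchanges a methoxy for a hydroxyl or brings two hydroxyls onto the ring, so the two methoxy steps bear on it only loosely; they show that single changes of a ring substituent on this core have stayed within the scatter. On that basis a step of a 1.2-fold lower number from compound 2 to compound 4 (0.06 log units; within the scatter) is expected, that is, no shift beyond the scatter. Compound 4 is therefore estimated at 10000 nM, within 4000 nM to 25000 nM.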

Compound 4, half-maximal inhibitory concentration: 25200 nM
Compound 4: middle estimate off by 2.5-fold (0.40 log units), on the low side; the measured number lies above the stated range.
By their numbers in this assay, from the lowest: compounds 3, 2, 1 and 4 (each within the scatter of the next, the first and the last beyond it).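

In this assay, within the data shown here, the exchange of 3-methoxyphenyl for 3,4-dihydroxyphenyl on a double-bonded chain carbon bound to a double-bonded ring carbon gives a 2.2-fold higher number from compound 2 to compound 4 (0.34 log units; beyond the scatter), the first step on the shared core to leave the scatter, though modestly, and it points towards a weaker inhibitor. The entering group carries hydrogen-bond donors and the leaving group has none, yet this one step changes the methoxy and both hydroxyls together and cannot separate their contributions. Nothing available accounts for the shift.

The compounds shown leave open whether a single hydroxyl on this aryl group would be enough to produce such a step. They also leave open how an amine or a carboxylic acid at this place would read in the same assay.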